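Pyridin-3-yl for Pyridin-4-yl on Two Related Cores

A few compounds are considered here, and "the series" means these few. Any claim that something is new, unique, unknown or untested is made for them only; others in the source may bear on it.

Measured so far:
compound 1 `COc1cccc(Nc2nccc(-c3ccncc3)n2)c1`: 400 nM
compound 2 `COc1cccc(Nc2nccc(-c3cccnc3)n2)c1`: 300 nM
compound 3 `COc1ccc(N(C)c2nccc(-c3ccncc3)n2)cc1`: > 24000 nM

In a functional assay for inhibition, with Homo sapiens as the target (a higher number here means a weaker inhibitor, a lower number a stronger inhibitor), compound 1 gives 400 nM and compound 2 gives 300 nM. The step of a 1.3-fold lower number from compound 1 to compound 2 (0.12 log units; within the scatter) follows the change (pyridin-3-yl in place of pyridin-4-yl on an aromatic carbon). For compound 3 the reading > 24000 nM is a limit of this assay and not a number; it sits at the limit of > 24000 nM in this assay, at which 1 of the 3 values shown sits. The difference between the core of compound 3 and the core of compound 1 is not broken down here.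

Compound 4 `COc1ccc(N(C)c2nccc(-c3cccnc3)n2)cc1` is not yet measured. It differs from compound 3 by pyridin-3-yl in place of pyridin-4-yl on an aromatic carbon, the same kind of change as from compound 1 to compound 2, the place now being meta to a large group rather than meta to a group of 9 heavy atoms. Because the step of a 1.3-fold lower number from compound 1 to compound 2 (0.12 log units; within the scatter) stayed within the scatter, compound 4 is expected to show a step that the limit leaves unreadable from compound 3 to compound 4 in this assay. The estimate for compound 4 is 30000 nM, between 10000 nM and 100000 nM, most likely reported again only as a limit.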

Compound 4, half-maximal inhibitory concentration: > 24000 nM
Compound 4: no number, only a limit; the forecaster's own chance of this, stated with the estimate: 80%; the middle value does not contradict the limit.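

No step can be read from compound 3 to compound 4, since both readings are limits and not numbers: the limit of > 24000 nM in this assay, at which 2 of the 4 values shown sit.

The compounds shown leave open whether pyridin-3-yl in place of pyridin-4-yl changes activity on the core of compound 3.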